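This account rests on a few compounds, and the source may have more. Where it says the series, first, only, none or still open, it means among the compounds named here.

Measured so far:
Compound 1 `C=CC1=C(C(=O)NCc2ccc(Cl)cc2)C(c2ccc(F)cc2)OC1`: in a functional assay on A549 cells (Homo sapiens) for cytotoxicity, read by MTT assay, with a stated time of 24 h (on this read-out higher numbers stand for weaker inhibition and lower numbers for stronger inhibition), compound 1 gives > 100000 nM, which is a limit of the assay.
Compound 2 `C=CC1=C(C(=O)NCc2ccc(Cl)cc2)C(c2ccc(OC)cc2)OC1`: in this assay compound 2 gives > 100000 nM, again a limit.
Compound 3 `C=CC1=C(C(=O)NCc2ccc(OC)c(OC)c2)C(c2ccc(F)cc2)OC1`: in this assay compound 3 gives > 100000 nM, also a limit.

Compound 1 therefore stands at the limit of this assay, with no number of its own. Among the measured compounds shown here, the one measured step, a step that the two limits leave unreadable from compound 1 to compound 2, is unreadable because the limit of > 100000 nM in this assay, at which 3 of the 3 values shown sit, holds both of its ends, and compound 3 adds nothing beyond that same limit.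

Compound 4 `C=CC1=C(C(=O)Nc2cccc(C)c2)C(c2ccc(F)cc2)OC1` differs from compound 1 by 3-methylphenyl in place of 4-chlorobenzyl on an amide-type nitrogen. For the measured compounds named here, no measured step touches this change, and the only step on record gives no size at all. The reader is left with the shared core, which in every tested form sits at the limit of this assay.

Compound 4 is therefore expected to sit at that limit as well, estimated at 100000 nM within 30000 nM to 300000 nM. The step expected from this estimate, a number no higher from compound 1 to compound 4 (the limit leaves the size open), means no change beyond the scatter.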

Compound 4, half-maximal inhibitory concentration: > 100000 nM
Compound 4: a limit, no number; the forecaster's own chance of this, stated with the estimate: 80%; the middle value sits exactly at the limit.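

In this assay compound 4 gives > 100000 nM, which is a limit. No step between compound 1 and compound 4 can be read, since both ends are limits: the limit of > 100000 nM in this assay, at which 4 of the 4 values shown sit.

The compounds shown leave open whether any form of the shared core gives a number of its own in this assay.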